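This account rests on a few compounds, and the source may have more. Where it says the series, first, only, none or still open, it means among the compounds named here.

Compound 1 `Cc1ccc(-n2cc(NC(=O)c3cccc(NS(=O)(=O)c4ccccc4)c3)cn2)cc1` and compound 2 `COc1ccc(-n2cc(NC(=O)c3cccc(NS(=O)(=O)c4ccccc4)c3)cn2)cc1` share one core and differ at a single point. In a functional assay on MCF7 cells (Homo sapiens) for inhibition, read by MTT assay, with a stated time of 48 h (a higher number here means a weaker inhibitor, a lower number a stronger inhibitor), compound 1 gives 1690 nM, while compound 2 gives 18700 nM. The change between them is methoxy in place of methyl on an aromatic carbon and it produced an 11-fold higher number from compound 1 to compound 2 (1.04 log units; beyond the scatter). Compound 3 `Cc1ccc(-n2cc(NC(=O)c3ccc(NS(=O)(=O)c4ccc(Cl)cc4)cc3)cn2)cc1` is built on a different core; how its core differs from that of compound 1 is not broken down here. In this assay compound 3 gives 3990 nM. Compound 4 `COc1ccc(-n2cc(NC(=O)c3ccc(NS(=O)(=O)c4ccc(Cl)cc4)cc3)cn2)cc1` has not yet been measured. It differs from compound 3 by methoxy in place of methyl on an aromatic carbon, the same change that separates compound 1 from compound 2. Among the measured compounds shown here, because that change gave an 11-fold higher number from compound 1 to compound 2 (1.04 log units; beyond the scatter), the expectation for compound 4 is a step of a 6.3-fold higher number from compound 3 to compound 4 (0.80 log units; beyond the scatter), kept somewhat smaller than the earlier one: only one example of the change has been measured, and the two cores are not the same, so the earlier result cannot simply be copied over. Compound 4 is therefore estimated at 25000 nM, with a likely range from 6000 nM to 100000 nM.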

Compound 4, half-maximal inhibitory concentration: 15600 nM
Beside the measured number, compound 4's estimate is 1.6-fold (0.20 log units) above it; the range from low to high includes it.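

In this assay, putting methoxy in place of methyl again gives a weaker inhibitor, with a 3.9-fold higher number from compound 3 to compound 4 (0.59 log units; beyond the scatter) on the second core. The direction of the change therefore carried over from one core to the other, but its size did not, as setting the two steps together shows: the same change on two cores in this assay, an 11-fold higher number (1.04 log units; beyond the scatter) from compound 1 to compound 2 and a 3.9-fold higher number (0.59 log units; beyond the scatter) from compound 3 to compound 4, 2.8-fold (0.45 log units) apart, beyond the scatter of two such steps. This shows that the 4-methoxyphenyl compound is the weaker of the pair on both cores, but two cores cannot show why the size differs or predict the step on a third core.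

The compounds shown carry only methyl or methoxy at this position of the ring, so it remains open how an amine, a hydroxyl group or a longer chain such as ethoxy would behave there. Going by these compounds, it also remains open which difference between the two cores sets the size of the step.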